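Chloro added beside trifluoromethyl on the piperazine aryl ring

This account rests on a few compounds, and the source may have more. Where it says the series, first, only, none or still open, it means among the compounds named here.

Measured so far:
compound 1, `Nc1scc(CN2CCN(c3ccc(F)cc3Cl)CC2)c1C(=O)c1ccc(Cl)cc1`, -70%
compound 2, `Nc1scc(CN2CCN(c3cccc(C(F)(F)F)c3)CC2)c1C(=O)c1ccc(Cl)cc1`, -80%

Both compounds share one core and differ only in the aryl group carried on the piperazine nitrogen. In a functional assay on CHO cells with adenosine receptor A1 (Homo sapiens) as the target, read by cAMP accumulation and immunoassay, with a stated time of 6 min, tested at 10 uM (on this read-out higher numbers stand for a weaker effect at the one concentration tested and lower numbers for a stronger effect), compound 1 gives -70%, and in this assay compound 2 gives -80%. For the measured compounds named here, the only measured step, a number 10 percentage points lower from compound 1 to compound 2 (within the scatter), is within the scatter, so the two compounds cannot be told apart on this read-out, and compound 2 stands level with compound 1.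

Compound 3, `Nc1scc(CN2CCN(c3ccc(Cl)c(C(F)(F)F)c3)CC2)c1C(=O)c1ccc(Cl)cc1`, has not been measured. It differs from compound 2 by chloro in place of hydrogen on an aromatic carbon. Going by the values given here, no measured step adds a chloro to this ring, so nothing in the data speaks directly to this change. Among the compounds with values here, the one step that exists, from the 2-chloro-4-fluorophenyl of compound 1 to the 3-(trifluoromethyl)phenyl of compound 2, stayed within the scatter despite a larger exchange of groups, which suggests this ring tolerates substituent changes without a large shift in this assay.

Compound 3 is therefore expected to give -80%, between -95% and -60%, a step of no change at the digits printed from compound 2 to compound 3 (within the scatter) that is expected to stay within the scatter.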

Compound 3, a percentage reported as activity, at one concentration (the size of the read-out at that concentration, not a potency): -60%
Compound 3: the middle estimate sits 20 percentage points below what was measured, within the range that was stated.
By their numbers in this assay, from the lowest: compounds 2, 1 and 3 (each within the scatter of the next, the first and the last beyond it).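

In this assay, chloro in place of hydrogen, ortho to the trifluoromethyl group and para to a large group, gave a number 20 percentage points higher from compound 2 to compound 3 (beyond the scatter). For the compounds shown here, this modest step is the first to pass the scatter, and it shows that the aryl ring of compound 2 does not tolerate every change at this carbon without a shift towards a weaker effect at the one concentration tested, whereas the earlier exchange of aryl groups gave no such evidence. The comparison with the other aryl group gives a number 10 percentage points higher from compound 1 to compound 3 (within the scatter), so the 4-chloro-3-(trifluoromethyl)phenyl and 2-chloro-4-fluorophenyl groups cannot be told apart on this read-out, and nothing available accounts for the shift seen on adding chloro.

The compounds shown leave open whether the shift belongs to chloro itself or to any group at this carbon, as a fluoro, methyl or methoxy group there could tell. They also leave open whether these differences at a single concentration would carry over to a full measure of potency.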